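Shortening a Side Chain on the Shared Core

The source may report more compounds than this note shows. Statements on the series, on what has been measured and on what is new or still open speak of the compounds shown alone.

Compound 1 `CC(C)n1cc(-c2ccnc3[nH]c(C4CCNCC4)cc23)ccc1=O` and compound 2 `CC(=O)N1CCC(c2cc3c(-c4ccc(=O)n(C(C)C)c4)ccnc3[nH]2)CC1` carry the shared core. In an ADME assay on microsomes from liver (Homo sapiens) for metabolic stability (a higher number here means faster removal of the compound, a lower number slower removal), compound 1 gives only a limit, < 3 uL/min. In this assay compound 2 also sits at a limit, < 3 uL/min. The step that the two limits leave unreadable from compound 1 to compound 2 therefore cannot be read. Within the data shown here, compound 3 `CC(C)Cn1cc(-c2ccnc3[nH]c(C4CCN(CC(=O)N(C)C)CC4)cc23)ccc1=O` gives the only true number in this assay, 21 uL/min, set apart from the limit of < 3 uL/min in this assay, at which 2 of the 3 values shown sit, where the other two values sit. Compound 4 `CCn1cc(-c2ccnc3[nH]c(C4CCN(CC(=O)N(C)C)CC4)cc23)ccc1=O` differs from compound 3 by methyl in place of isopropyl on a saturated chain carbon bound to an aromatic nitrogen. Among the measured compounds shown here, no measured step touches this group, so none bears on the change, and no movement beyond the usual scatter is expected. Compound 4 is expected to give about 15 uL/min in this assay, between 6 uL/min and 40 uL/min. The expected step is a 1.4-fold lower number from compound 3 to compound 4 (0.15 log units; within the scatter).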

Compound 4, intrinsic clearance in a liver preparation (reported as CLH), per the amount of preparation that the assay uses: < 3 uL/min
Compound 4 gave a limit, no number (the forecaster's own chance of this, stated with the estimate: 15%); middle value at least 5.0-fold (0.69 log units) from the limit.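

Replacing isopropyl with methyl on a saturated chain carbon bound to an aromatic nitrogen, which reads as isobutyl to ethyl one bond further out, gives an at least 7.0-fold lower number from compound 3 to compound 4 (0.84 log units; beyond the scatter). Among these compounds, this is the first readable step, and it shows that the number in this assay responds to this position, which no earlier step touched. Compound 4 gives only a limit, so the full size of the step stays unknown, and compound 4 joins most of the series: the limit of < 3 uL/min in this assay, at which 3 of the 4 values shown sit.

The compounds shown leave open how a propyl chain or a cyclopropyl group would read at this position. They also leave open whether the same shortening would give a similar step with an acetyl on the amine nitrogen in a ring.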